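Anilide series on a shared core: dropping the chloro

The compounds below may be only part of what the source reports. "The series", "measured", "known", "first", "only" and "open" are said of these compounds alone.

Measured:
compound 2 `O=C(CSc1nc2cccnc2[nH]1)Nc1ccccc1Cl` — 19%
compound 1 `CCOC(=O)c1cccc(NC(=O)CSc2nc3cccnc3[nH]2)c1` — 15%

In an assay on isolated protein for inhibition of Ectonucleotide pyrophosphatase/phosphodiesterase family member 1 (Homo sapiens), tested at 10 uM (a higher number here means more inhibition at the concentration tested (going by the name of the read-out), a lower number less inhibition), compound 2 gives 19%, the higher of the two numbers, while compound 1 gives 15%; the gap lies within the scatter, so the two numbers count as level. Compound 3 `O=C(CSc1nc2cccnc2[nH]1)Nc1ccccc1` is not yet measured. It differs from compound 2 in one place: hydrogen in place of chloro on an aromatic carbon. Within the data shown here, no step of this kind is known, so no size beyond the scatter is expected in this assay, if anything a slightly lower number. Compound 3 is expected to give 14%, within 2% to 28%, a step of a number 5 percentage points lower from compound 2 to compound 3 (within the scatter) that stays within the scatter.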

Compound 3, a percentage reported as inhibition, at one concentration (the size of the read-out at that concentration, not a potency): 30%
The estimate for compound 3 lay 16 percentage points below the measured number; the whole stated range lies below it.
By their numbers in this assay, from the lowest: compounds 1 and 2 (each within the scatter of the next); then compound 3.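

In this assay, the change from 2-chlorophenyl to phenyl gives a step beyond the scatter, a number 11 percentage points higher from compound 2 to compound 3 (beyond the scatter), so the chloro is not required for the inhibition seen in this series. Hydrogen in place of ethoxycarbonyl also gives a step beyond the scatter, a number 15 percentage points higher from compound 1 to compound 3 (beyond the scatter). Among these one-place changes, each substituted ring gives a lower number than the phenyl of compound 3.

On these data alone, whether a methyl, an amine or a carboxylic acid on this ring would match or exceed compound 3 remains open. Nothing available bears on the reason for either step.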